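The compounds below may be only part of what the source reports. "The series", "measured", "known", "first", "only" and "open" are said of these compounds alone.

The three measured compounds in a functional assay on MDA-MB-468 cells (Homo sapiens) for cytotoxicity, read by MTT assay, with a stated time of 48 h (a higher number here means a weaker inhibitor, a lower number a stronger inhibitor), are:

Compound 1, `Cc1ccc(-c2csc(NC(=O)COc3ccccc3C)n2)cc1`, with a value of 52100 nM.
Compound 2, `Cc1ccc(-c2csc(NC(=O)COc3ccccc3C(C)C)n2)cc1`, with a value of 55500 nM.
Compound 3, `Cc1ccccc1OCC(=O)Nc1nc(-c2ccc(Br)cc2)cs1`, with a value of 44900 nM.

All three values sit close together, and neither of the two single-point changes among them moved the read-out beyond the usual scatter. Compound 4, `CC(C)c1ccccc1OCC(=O)Nc1nc(-c2ccc(Br)cc2)cs1`, has not yet been measured. It differs from compound 3 by isopropyl in place of methyl on an aromatic carbon. This is the same change that separates compound 1 from compound 2; among the compounds shown it occurs twice in all, and in the measured pair it produced a 1.1-fold higher number from compound 1 to compound 2 (0.03 log units; within the scatter). The cores of compound 3 and compound 1 differ by bromo in place of methyl on an aromatic carbon, a difference that gave a 1.2-fold lower number from compound 1 to compound 3 (0.06 log units; within the scatter).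

Going by the values given here, with only one measured instance of the change, the expectation for compound 4 rests on that single pair. Because a 1.1-fold higher number from compound 1 to compound 2 (0.03 log units; within the scatter) lies within the scatter, the step of a 1.1-fold higher number from compound 3 to compound 4 (0.03 log units; within the scatter) is expected to be of about the same small size. Compound 4 is therefore estimated at 48000 nM in this assay, with an expected range from 25000 nM to 95000 nM.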

Compound 4, half-maximal inhibitory concentration: 50900 nM
Estimate against measurement, compound 4: 1.1-fold (0.03 log units) below; the range from low to high includes it.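

In this assay, isopropyl in place of methyl on the bromo-bearing core gave a 1.1-fold higher number from compound 3 to compound 4 (0.05 log units; within the scatter), and this step matches the earlier one: the same change on two cores in this assay, a 1.1-fold higher number (0.03 log units; within the scatter) from compound 1 to compound 2 and a 1.1-fold higher number (0.05 log units; within the scatter) from compound 3 to compound 4, 1.1-fold (0.03 log units) apart, within the scatter of two such steps. Bromo in place of methyl, now read with isopropyl on the other ring, gave a 1.1-fold lower number from compound 2 to compound 4 (0.04 log units; within the scatter), and it too agrees with its earlier counterpart: the same change on two cores in this assay, a 1.2-fold lower number (0.06 log units; within the scatter) from compound 1 to compound 3 and a 1.1-fold lower number (0.04 log units; within the scatter) from compound 2 to compound 4, 1.1-fold (0.03 log units) apart, within the scatter of two such steps. These pairs show that neither change moved the read-out on either core, so the four compounds behave alike, but they do not show that a change carries over with a consistent size, since every step is within the scatter and there is no real effect to transfer.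

The compounds shown hold only methyl, isopropyl and bromo at the two varied positions, so it stays open whether an amine, a carboxylic acid or a longer chain there would shift the read-out on either core. From the compounds shown here alone, it also stays open whether a change with a step beyond the scatter would carry from one core to the other.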